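Hydroxy substitution in a fused imide series

This account rests on a few compounds, and the source may have more. Where it says the series, first, only, none or still open, it means among the compounds named here.

Measured compounds:
compound 1 `O=C1NC(=O)c2c1c1c(O)cccc1c1[nH]c3ccccc3c21`, 19200 nM in a functional assay on L1210 cells (Mus musculus) for antiproliferative activity, with a stated time of 4 h; on this read-out lower numbers stand for stronger inhibition and higher numbers for weaker inhibition
compound 2 `O=c1ccc(=O)c2c1c1[nH]c3ccccc3c1c1c(=O)[nH]c(=O)c21`, 6800 nM in this assay
compound 3 `O=c1ccc(=O)c2c1c1[nH]c3ccc(O)cc3c1c1c(=O)[nH]c(=O)c21`, 8400 nM in this assay

Compound 4 `O=C1NC(=O)c2c1c1c(O)ccc(O)c1c1[nH]c3ccccc3c21` is not yet measured. It arises from compound 1 by hydroxy in place of hydrogen on an aromatic carbon. The same kind of change turns compound 2 into compound 3, (hydroxy in place of hydrogen on an aromatic carbon), though the surroundings are not the same: in compound 4 the entering hydroxy sits ortho to a fused ring, meta to a fused ring and para to a hydroxy group, whereas in compound 3 it sits meta to a fused ring and para to a fused ring. The difference between the core of compound 1 and that of compound 2 is not broken down here. In this assay the earlier step was a 1.2-fold higher number from compound 2 to compound 3 (0.09 log units; within the scatter). On that basis the step of a 1.1-fold lower number from compound 1 to compound 4 (0.03 log units; within the scatter) is expected to be of similar, modest size. Compound 4 is therefore estimated at 18000 nM, with a likely range from 8000 nM to 40000 nM.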

Compound 4, half-maximal inhibitory concentration: 1100 nM
Compound 4: middle estimate off by 16-fold (1.21 log units), on the high side; measured number below the stated range.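

On the core of compound 1, hydroxy in place of hydrogen gives a 17-fold lower number from compound 1 to compound 4 (1.24 log units; beyond the scatter), where the entering hydroxy sits para to a hydroxy group. In this assay the size of this change therefore does not carry from one core to the other: the same change on two cores in this assay, a 1.2-fold higher number (0.09 log units; within the scatter) from compound 2 to compound 3 and a 17-fold lower number (1.24 log units; beyond the scatter) from compound 1 to compound 4, 22-fold (1.33 log units) apart, beyond the scatter of two such steps. With one pair on each core, and the entering hydroxy placed differently in each, these results do not separate the role of the core from that of the place of substitution.

Open, on these data alone, is whether the large step requires hydroxy itself, which a methoxy group or an amine entering at the same place on the core of compound 1 would test. Also open, as far as these compounds go, is how hydroxy behaves at other places on either core.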